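One Aryl Swap on a Shared Core

The compounds below may be only part of what the source reports. "The series", "measured", "known", "first", "only" and "open" are said of these compounds alone.

Of the compounds shown here, two have so far been measured in an ADME assay on HEK293 cells (Homo sapiens) for cytotoxicity, read by MTT assay, with a stated time of 24 h; a lower number here means a stronger inhibitor, a higher number a weaker inhibitor. Compound 1 `O=[N+]([O-])c1ccc2nc(NCc3ccc(C(F)(F)F)cc3)c(N3CCNCC3)nc2c1` gives 9.61 ug/mL in this assay. Compound 2 `CN(C)CCCNc1nc2cc([N+](=O)[O-])ccc2nc1NCc1ccc(Br)cc1` gives 9.63 ug/mL in this assay. Compound 2 holds the highest of the two numbers, but its nearest neighbour, compound 1, sits within the usual scatter of it, so the two values are not distinguishable, and compound 1 and compound 2 differ from each other in more than one place, so no single step can be read from them.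

Compound 3 `COc1ccccc1CNc1nc2ccc([N+](=O)[O-])cc2nc1NCCCN(C)C` has not yet been tested in this assay. It differs from compound 2 in one place: 2-methoxyphenyl in place of 4-bromophenyl on a saturated chain carbon bound to a nitrogen on an aromatic ring

Within the data shown here, no measured step in this assay speaks directly to this kind of change. Among the measured compounds shown here, with only two values in hand, and those two alike, there is no basis for expecting a shift in either direction; the expectation is a step of no more than the scatter, with a wide range to reflect how little is known. Compound 3 is therefore expected to give about 10 ug/mL in this assay, plausibly between 5 ug/mL and 20 ug/mL. The step this estimate implies is a 1.0-fold higher number from compound 2 to compound 3 (0.02 log units; within the scatter), expected to be within the scatter.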

Compound 3, half-maximal inhibitory concentration: 36.1 ug/mL
Compound 3: middle estimate off by 3.6-fold (0.56 log units), on the low side; measured number outside the range, above it.
By their numbers in this assay, from the lowest: compounds 1 and 2 (each within the scatter of the next); then compound 3.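

In this assay the change to 2-methoxyphenyl from 4-bromophenyl, on a saturated chain carbon bound to a nitrogen on an aromatic ring, gives a 3.7-fold higher number from compound 2 to compound 3 (0.57 log units; beyond the scatter) and so shows that the number can respond to the aryl group at this place. Among these compounds, the alike values of compound 1 and compound 2 could not show this, since those two compounds differ in more than one place and offer no single step to read. Nothing measured here accounts for the step, which replaces a ring carrying bromine with one carrying methoxy and also changes the number in the group's name, so its cause stays unassigned.

The compounds shown do not separate the loss of the 4-bromo group from the arrival of the 2-methoxy group, and a plain phenyl at the same place would offer a simpler point of comparison for both. Also open, as far as these compounds go, is whether the step would hold on the core of compound 1, which carries a piperazine where compound 2 and compound 3 carry their dimethylaminopropyl chain.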